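The source may hold more compounds than are shown below. What is called first, only, known or untested is meant among the compounds shown, and "the series" means these compounds.

In an ADME assay on the whole organism for metabolic stability, with Rattus norvegicus as the target (a lower number here means that the compound disappears faster, a higher number that the compound lasts longer), compound 1 `O=S(=O)(c1ccc(O)c2ncccc12)C1CCCC1` gives 0.18 h while compound 2 `O=S(=O)(c1ccc(F)cc1)c1cc(F)c(O)c2ncccc12` gives 4.5 h and so stands highest of the two, a gap beyond the usual scatter. Compound 3 `O=S(=O)(c1cc(F)c(O)c2ncccc12)C1CCCC1` differs from compound 2 by cyclopentyl in place of 4-fluorophenyl on a sulfonyl sulfur with cyclopentyl in place of 4-fluorophenyl on a sulfonyl sulfur. Among the measured compounds shown here, no measured step covers this change, but compound 1 also carries cyclopentyl on its sulfonyl sulfur and gives 0.18 h as its number, so a large fall beyond the scatter is expected. The expected change is a 7.5-fold lower number from compound 2 to compound 3 (0.88 log units; beyond the scatter) in size. For compound 3 the estimate is 0.6 h with a likely range from 0.2 h to 1.8 h around it.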

Compound 3, half-life: 7.7 h
Compound 3: middle estimate off by 13-fold (1.11 log units), on the low side; the whole stated range lies below it.
By their numbers in this assay, from the lowest: compound 1; then compounds 2 and 3 (each within the scatter of the next).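

In this assay cyclopentyl in place of 4-fluorophenyl on a sulfonyl sulfur gives a 1.7-fold higher number from compound 2 to compound 3 (0.23 log units; within the scatter) and so, with the fluoro present, the two groups cannot be told apart. Fluoro in place of hydrogen on an aromatic carbon gives a 43-fold higher number from compound 1 to compound 3 (1.63 log units; beyond the scatter) so the short half-life of compound 1 goes with the missing fluoro, not with cyclopentyl alone. Nothing available explains why this single atom matters so much. From the compounds shown here alone, whether 4-fluorophenyl also depends on that fluoro remains open. So does how an amine or a longer chain on the sulfonyl sulfur would behave.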